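Trichloroethyl Ester Replaces Hexyl Ester: Gastric Stability Outlook

The source may report more compounds than this note shows. Statements on the series, on what has been measured and on what is new or still open speak of the compounds shown alone.

Measured compounds:
- compound 1, `CCOc1cc(NC(=O)C2(NC(=O)c3ccc4c(C5CCCC5)c(-c5ncc(Cl)cn5)n(C)c4c3)CCC2)ccc1/C=C/C(=O)N[C@@H](CCCNC(=N)N)C(N)=O`: 0.467 h
- compound 2, `CCCCCCOC(=O)/C=C/c1ccc(NC(=O)C2(NC(=O)c3ccc4c(C5CCCC5)c(-c5ncc(Cl)cn5)n(C)c4c3)CCC2)cc1OCC`: 0.883 h

In an ADME assay on stomach for pharmacokinetics, in simulated gastric fluid (a lower number here means that the compound disappears faster, a higher number that the compound lasts longer), compound 1 gives 0.467 h. In this assay compound 2 gives 0.883 h. Going by the values given here, the only step among the measured compounds, a 1.9-fold higher number from compound 1 to compound 2 (0.28 log units; within the scatter), lies within the scatter, so the two numbers cannot be told apart and compound 2 cannot be called more stable than compound 1.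

Compound 3, `CCOc1cc(NC(=O)C2(NC(=O)c3ccc4c(C5CCCC5)c(-c5ncc(Cl)cn5)n(C)c4c3)CCC2)ccc1/C=C/C(=O)OCC(Cl)(Cl)Cl`, has not yet been measured in this assay. It differs from compound 2 by trichloromethyl in place of pentyl on a saturated chain carbon bound to an oxygen next to a carbonyl group. Among the compounds with values here, no measured step touches this position: the one known step, a 1.9-fold higher number from compound 1 to compound 2 (0.28 log units; within the scatter), changes the group on the carbonyl carbon itself and stays within the scatter. There is therefore no basis in the measured compounds for expecting a shift beyond the scatter in either direction, and the expected step of a 1.1-fold lower number from compound 2 to compound 3 (0.04 log units; within the scatter) is one that stays within the scatter. Compound 3 is estimated in this assay at 0.8 h, with a range from 0.4 h to 1.8 h.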

Compound 3, half-life: 1.75 h
Compound 3: middle estimate off by 2.2-fold (0.34 log units), on the low side; the measured number falls inside the stated range.
By their numbers in this assay, from the lowest: compounds 1, 2 and 3 (each within the scatter of the next, the first and the last beyond it).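

Exchanging pentyl for trichloromethyl on a saturated chain carbon bound to an oxygen next to a carbonyl group gives a 2.0-fold higher number from compound 2 to compound 3 (0.30 log units; within the scatter) in this assay and so, at the first test of this position, produces no difference that can be told from repeat measurement. Going by these compounds alone, the wider replacement on the carbonyl carbon does separate two compounds, since the data show a 3.7-fold higher number from compound 1 to compound 3 (0.57 log units; beyond the scatter) and this is the first step here to pass the scatter, whereas the hexyl ester of compound 2 could not be told apart from compound 1. Nothing measured among these compounds offers an explanation for either result.

The compounds shown leave open whether an amine or a carboxylic acid on that chain carbon, or a chain longer than hexyl, would carry the half-life beyond the scatter from compound 2. They also leave open whether a plain ethyl ester or a 2,2,2-trifluoroethyl ester would last as long as compound 3 does, and so whether the chlorine atoms matter at all.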